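This account rests on a few compounds, and the source may have more. Where it says the series, first, only, none or still open, it means among the compounds named here.

Measured so far:
Compound 1 `O/N=C(\COc1cccc2ccccc12)c1ccc(F)cc1`: > 50000 nM
Compound 2 `O/N=C(\COc1cccc2ccccc12)c1ccc(C(F)(F)F)cc1`: 46400 nM

In an ADME assay on NPC-TW01 cells (Homo sapiens) for cytotoxicity, read by MTT assay (on this read-out higher numbers stand for weaker inhibition and lower numbers for stronger inhibition), compound 1 gives > 50000 nM, which is a limit of the assay and not a number. Going by the values given here, compound 2 gives 46400 nM, the only exact value so far. Compound 1 stands at the limit of > 50000 nM in this assay, at which 1 of the 2 values shown sits.

Compound 3 `O/N=C(\COc1cccc2ccccc12)c1ccc(-c2ccccc2)cc1` differs from compound 2 by phenyl in place of trifluoromethyl on an aromatic carbon. This places phenyl in place of trifluoromethyl on an aromatic carbon of the six-membered aromatic ring, para to a large group.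

Among the compounds with values here, only one measured step bears on this change: an at least 1.0-fold lower number from compound 1 to compound 2 (0.03 log units; that floor lies within the scatter). It also alters the same substituent, but it replaces fluoro with trifluoromethyl, and phenyl has not yet been tested. With so little evidence, no step beyond the scatter is expected in this assay, though a slightly lower number is thought possible. Compound 3 may also return only a limit, as compound 1 did.

The expected step is a 1.3-fold lower number from compound 2 to compound 3 (0.12 log units; within the scatter). For compound 3, the estimated value is 35000 nM, with an expected range of 15000 nM to 50000 nM.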

Compound 3, half-maximal inhibitory concentration: > 50000 nM
Compound 3: only a limit was reported; the forecaster's own chance of this, stated with the estimate: 35%; at least 1.4-fold (0.15 log units) between middle value and limit.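

In this assay, going by these compounds alone, phenyl in place of trifluoromethyl on an aromatic carbon, para to a large group, gives an at least 1.0-fold higher number from compound 2 to compound 3 (0.03 log units; that floor lies within the scatter), so the first change at this position to bring in a whole aromatic ring shows no movement that can be told from the scatter, though the true size of the step stays hidden. Compound 3 gives > 50000 nM, which is a limit of the assay and not a number. The step between compound 1 and compound 3 cannot be read, yet phenyl now joins fluoro at that limit, leaving the trifluoromethyl compound as the only one with an exact value: the limit of > 50000 nM in this assay, at which 2 of the 3 values shown sit.

The compounds shown leave open whether an amine, a carboxylic acid or a longer chain on this aromatic carbon would bring the number down by a step beyond the scatter. They also leave open how far above the limit compound 1 and compound 3 really lie, and so whether fluoro and phenyl differ from each other at all.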